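The source may hold more compounds than are shown below. What is called first, only, known or untested is meant among the compounds shown, and "the series" means these compounds.

Compound 1 `COc1cc(-n2cnc3ccc(-c4ccccc4Cl)cc32)cc(OC)c1OC` is the starting point of this step. In a functional assay on SGC-7901 cells (Homo sapiens) for antiproliferative activity, read by MTT assay, with a stated time of 72 h (a higher number here means a weaker inhibitor, a lower number a stronger inhibitor), compound 1 gives > 10000 nM, which is a limit of the assay rather than a measured number (the limit of > 10000 nM in this assay, at which 1 of the 3 values shown sits). Two measured neighbours show how the assay answers to a change of the same pendant ring on the shared core. Compound 2 `COc1cc(-n2cnc3ccc(-c4ccc(C)cc4F)cc32)cc(OC)c1OC` gives 5650 nM in this assay, and the resulting at least 1.7-fold lower number from compound 1 to compound 2 (0.24 log units; that floor lies within the scatter) is a floor that stays within the scatter. Compound 3 `COc1cc(-n2cnc3ccc(-c4cccc(N)c4)cc32)cc(OC)c1OC` gives 21 nM, so that an at least 470-fold lower number from compound 1 to compound 3 (2.67 log units; beyond the scatter) and a 270-fold lower number from compound 2 to compound 3 (2.43 log units; beyond the scatter) are both large.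

Compound 4 `COc1cc(-n2cnc3ccc(-c4cccc([N+](=O)[O-])c4)cc32)cc(OC)c1OC` is not yet measured. It differs from compound 1 in one place: 3-nitrophenyl in place of 2-chlorophenyl on an aromatic carbon. The step to compound 3 bears most on this change, since 3-aminophenyl and 3-nitrophenyl both replace 2-chlorophenyl; the step to compound 2 bears on it only in showing that not every change at this ring moves the number beyond the scatter. A nitro group is not an amino group, so a drop clearly smaller than an at least 470-fold lower number from compound 1 to compound 3 (2.67 log units; beyond the scatter) but beyond the scatter is expected, giving an at least 12-fold lower number from compound 1 to compound 4 (1.09 log units; beyond the scatter). Compound 4 is therefore estimated to give 800 nM in this assay, within a range from 100 nM to 6000 nM.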

Compound 4, half-maximal inhibitory concentration: 380 nM
Compound 4: the middle estimate sits 2.1-fold (0.32 log units) above what was measured; the range from low to high includes it.
By their numbers in this assay, from the lowest: compound 3; then compound 4; then compound 2. At a limit, above all of these: compound 1.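

In this assay, nitro in place of amino gives an 18-fold higher number from compound 3 to compound 4 (1.26 log units; beyond the scatter), so with the pendant ring otherwise unchanged, the identity of this one group moves the number far beyond the scatter. Even so, 3-nitrophenyl in place of 2-fluoro-4-methylphenyl gives a 15-fold lower number from compound 2 to compound 4 (1.17 log units; beyond the scatter), which means that among these four compounds the two 3-substituted phenyl rings, in compound 3 and compound 4, give the two lowest numbers, and the amino group is not the only group that gives a number well below that of compound 2. Against 2-chlorophenyl, the change gives an at least 26-fold lower number from compound 1 to compound 4 (1.42 log units; beyond the scatter), which is only a floor, since compound 1 stands at a limit of the assay rather than at a measured number: the limit of > 10000 nM in this assay, at which 1 of the 4 values shown sits.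

The compounds shown leave open whether the low number of compound 3 would hold with a methylamino, dimethylamino or acetamido group in place of the amino group, or with a hydroxyl or methoxy group there. They also leave open how amino or nitro would fare at any other place on the pendant ring, since each stands here at only one.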